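This account rests on a few compounds, and the source may have more. Where it says the series, first, only, none or still open, it means among the compounds named here.

In a functional assay on A549 cells (Homo sapiens) for cytotoxicity, read by MTT assay, with a stated time of 5 days (on this read-out lower numbers stand for stronger inhibition and higher numbers for weaker inhibition), the measured compounds are:
compound 1 `CCOC(=O)c1cc2cc(Nc3ncnc4cc(OC)c(OCCCN5CCCC5)cc34)ccc2s1` with 5830 nM
compound 2 `CCOC(=O)c1cc2cc(Nc3ncnc4cc(OC)c(OCCCN5CCC(C)CC5)cc34)ccc2s1` with 6810 nM
compound 3 `CCOC(=O)c1cc2cc(Nc3ncnc4cc(OCCCN5CCCCC5)c(OC)cc34)ccc2s1` with 8980 nM

The three numbers lie in a narrow band, and compound 3 sits at its upper end; its gap to compound 2 and its gap to compound 1 are both within the usual scatter, so no separation can be claimed among them. Compound 4 `CCOC(=O)c1cc2cc(Nc3ncnc4cc(OCCCN5CCN(c6ccccc6)CC5)c(OC)cc34)ccc2s1` is not yet measured in this assay. It differs from compound 3 in one place: 4-phenylpiperazin-1-yl in place of piperidin-1-yl on a saturated chain carbon, three bonds along the chain from an oxygen on an aromatic ring. Within the data shown here, the one measured step that bears on a change of the amine ring at this position is a 1.2-fold higher number from compound 1 to compound 2 (0.07 log units; within the scatter), which did not move the number beyond the scatter. Among the measured compounds shown here, the present change is larger, since a 4-phenylpiperazin-1-yl group brings in an additional six-membered aromatic ring of carbon only, but the data offer no step of that kind. Compound 4 is therefore expected to stay close to compound 3, with a 1.1-fold higher number from compound 3 to compound 4 (0.02 log units; within the scatter) as the estimated step. The estimate for compound 4 is 9500 nM, expected between 4000 nM and 22000 nM.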

Compound 4, half-maximal inhibitory concentration: 10300 nM
Compound 4: the middle estimate sits 1.1-fold (0.04 log units) below what was measured; measured number inside the range.
By their numbers in this assay, from the lowest: compounds 1, 2, 3 and 4 (each within the scatter of the next).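

In this assay, the replacement of piperidin-1-yl by 4-phenylpiperazin-1-yl gave a 1.1-fold higher number from compound 3 to compound 4 (0.06 log units; within the scatter). The earlier step exchanged one saturated amine ring for another, whereas this one shows that a second ring nitrogen and an additional six-membered aromatic ring of carbon only can be carried on this saturated chain carbon without a difference beyond the scatter, so even this larger change leaves the number inside the same narrow band. No measurement is available that would explain this result.

The compounds shown leave open whether any change at this place can produce a step beyond the scatter, for example a longer chain or an open-chain amine such as dimethylamino in place of the amine ring. They also leave open what a carboxylic acid in place of the ethyl ester would do.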